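Fluoro Added Where All Three Analogues Sit at the Limit

The source may hold more compounds than are shown below. What is called first, only, known or untested is meant among the compounds shown, and "the series" means these compounds.

Compound 2 `Cc1ccc(-c2ccc(C(=O)Nc3ccc(Oc4ccnc5[nH]ccc45)cc3)nc2)cc1` was tested in a functional assay on MCF7 cells (Homo sapiens) for cytotoxicity, read by MTT assay, with a stated time of 72 h (on this read-out higher numbers stand for weaker inhibition and lower numbers for stronger inhibition), and reached only the limit of the assay, reported as > 10000 nM. Compound 1 `O=C(Nc1ccc(Oc2ccnc3[nH]ccc23)cc1)c1ccc(-c2ccc(Cl)cc2)cn1` likewise sits at the assay limit, giving > 10000 nM in this assay. Compound 3 `CCc1ccc(-c2ccc(C(=O)Nc3ccc(Oc4ccnc5[nH]ccc45)cc3)nc2)cc1` gives > 10000 nM in this assay, again a limit rather than a number.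

Three steps connect these compounds, and none of them can be read: a step that the two limits leave unreadable from compound 1 to compound 2, a step that the two limits leave unreadable from compound 1 to compound 3 and a step that the two limits leave unreadable from compound 2 to compound 3, because of the limit of > 10000 nM in this assay, at which 3 of the 3 values shown sit. The numbers therefore show only that swapping chloro, methyl or ethyl on the outer aromatic ring left all three compounds beyond the reach of the assay.

Compound 4 `Cc1ccc(-c2ccc(C(=O)Nc3ccc(Oc4ccnc5[nH]ccc45)c(F)c3)nc2)cc1` keeps the whole of compound 2 and adds one atom: fluoro in place of hydrogen on an aromatic carbon, on an aromatic carbon of a six-membered aromatic ring of carbon only, ortho to a large group and meta to a large group. For the measured compounds named here, no measured step bears directly on this change, and the three unreadable steps give no direction. The expectation is therefore a step that the limit leaves unreadable from compound 2 to compound 4 from compound 2 to compound 4, most likely another limit. The estimate for compound 4 in this assay is 15000 nM, with a range from 4000 nM to 60000 nM.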

Compound 4, half-maximal inhibitory concentration: 8020 nM
Compound 4: middle estimate off by 1.9-fold (0.27 log units), on the high side, and the stated range covers the measured number.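

For the compounds shown here, compound 4 is the first compound here to give a number rather than a limit: in this assay compound 4 gives 8020 nM. Fluoro in place of hydrogen on an aromatic carbon, ortho to a large group and meta to a large group, gives an at least 1.2-fold lower number from compound 2 to compound 4 (0.09 log units; that floor lies within the scatter), so this one added atom cannot yet be called a gain, although it does show that this position of the central carbon ring accepts a change while leaving a value that can be read. The step has only a lower bound, with no upper end, and its true size stays unknown: the limit of > 10000 nM in this assay, at which 3 of the 4 values shown sit.

Going by these compounds, whether the same fluoro would also bring compound 1 or compound 3 to a readable value remains open, and only those pairs could show whether the result holds beyond the methyl-bearing compound 2. On these data alone, it also remains open how other groups at this same position would compare with fluoro, such as a methoxy group, an amine or a nitrile, and whether any of them would move the number clearly beyond the usual scatter.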